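Methoxy count on the aryl ring: three, and two

A few compounds are considered here, and "the series" means these few. Any claim that something is new, unique, unknown or untested is made for them only; others in the source may bear on it.

Compound 2 `COc1cc(-c2cc(/C=C/C(=O)c3ccc(N)cc3)[nH]n2)cc(OC)c1OC` carries three methoxy groups on the aromatic ring attached to the shared core; compound 1 `COc1ccc(-c2cc(/C=C/C(=O)c3ccc(N)cc3)[nH]n2)cc1` carries one. For the measured compounds named here, in a functional assay on M14 cells (Homo sapiens) for inhibition, read by sulforhodamine B assay, with a stated time of 48 h (a higher number here means a weaker inhibitor of growth, a lower number a stronger inhibitor of growth), compound 2 gives 1830 nM, the lowest of the two numbers so far. Compound 1 gives 2670 nM in this assay, which lies within the scatter of the value of compound 2, so the two cannot be ordered. Compound 3 `COc1ccc(-c2cc(/C=C/C(=O)c3ccc(N)cc3)[nH]n2)cc1OC` is the next member: relative to compound 2 it has hydrogen in place of methoxy on an aromatic carbon. Going by the values given here, no measured pair bears directly on this change. Since compound 1 at 2670 nM and compound 2 at 1830 nM fall within the scatter of each other, no shift beyond the scatter is expected from removing one methoxy. Compound 3 is therefore expected to land between the two, with a 1.2-fold higher number from compound 2 to compound 3 (0.08 log units; within the scatter) amounting to no change beyond the scatter. The estimate for compound 3 in this assay is 2200 nM, with a range from 1100 nM to 4400 nM.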

Compound 3, concentration for 50% growth inhibition: 2280 nM
Compound 3: middle estimate off by 1.0-fold (0.02 log units), on the low side; the measured number falls inside the stated range.
By their numbers in this assay, from the lowest: compounds 2, 3 and 1 (each within the scatter of the next).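

In this assay, hydrogen in place of methoxy on an aromatic carbon gives a 1.2-fold higher number from compound 2 to compound 3 (0.10 log units; within the scatter), and methoxy in place of hydrogen on an aromatic carbon gives a 1.2-fold lower number from compound 1 to compound 3 (0.07 log units; within the scatter), so each single change on this ring stays within the scatter. The earlier pair differed in two places, whereas these steps read one methoxy at a time and show that, among these compounds, neither hydrogen nor methoxy at the changed carbons separates from the other. The data on hand offer no explanation for this flat result.

Going by these compounds, whether a hydroxyl, a fluorine or a longer alkoxy chain on these carbons would move the number beyond the scatter remains open. So does the effect of removing the last methoxy from this ring, leaving hydrogen alone.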